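The compounds below may be only part of what the source reports. "The series", "measured", "known", "first", "only" and "open" are said of these compounds alone.

Compound 3 `Nc1ncnc2c1ccn2C(CO)OC(CO)CO` offers no exact number to start from. In an ADME assay on cells (kidney, Cercopithecidae) for cytotoxicity (on this read-out higher numbers stand for weaker inhibition and lower numbers for stronger inhibition), compound 3 gives > 100000 nM, which is a limit of the assay. Compound 1 `N#Cc1cn(COC(CO)CO)c2ncnc(N)c12` gives > 100000 nM, also a limit. Compound 2 `NC(=S)c1cn(COC(CO)CO)c2ncnc(N)c12` gives > 100000 nM, again a limit. All the data so far therefore sit in one place: the limit of > 100000 nM in this assay, at which 3 of the 3 values shown sit.

Compound 4 `N#Cc1cn(C(CO)OC(CO)CO)c2ncnc(N)c12` arises from compound 3 through one change, cyano in place of hydrogen on an aromatic carbon. Within the data shown here, the only measured step at such a carbon is a step that the two limits leave unreadable from compound 1 to compound 2, and with a limit at both ends it gives no size to work from. The closest guide is compound 1, which already carries cyano and stays at the limit of > 100000 nM. No step beyond the usual scatter is therefore expected in this assay, in either direction. The expected change is a number no higher from compound 3 to compound 4 (the limit leaves the size open). For compound 4 the estimated value is 100000 nM, with an expected range of 50000 nM to 200000 nM.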

Compound 4, half-maximal inhibitory concentration: > 100000 nM
Compound 4: a limit, no number; the forecaster's own chance of this, stated with the estimate: 90%; the middle value lies on the limit itself.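

Compound 4 gives only a limit of the assay, so the steps to it from compound 3 and from compound 1 cannot be read, and everything stays in one place: the limit of > 100000 nM in this assay, at which 4 of the 4 values shown sit. The compounds shown leave open at what concentration, if any, any of them would register inhibition in this assay.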